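Cytotoxicity series: fluoro for methoxy, two cores

This account rests on a few compounds, and the source may have more. Where it says the series, first, only, none or still open, it means among the compounds named here.

Measured compounds:
compound 1, `COc1cccc(/C=C/C(=O)c2cc(NC(C)=O)ccc2O)c1`, 93700 nM
compound 2, `CC(=O)Nc1ccc(O)c(C(=O)/C=C/c2cccc(F)c2)c1`, 78600 nM
compound 3, `COc1ccc(-c2cc(=O)c3cc(N)ccc3o2)cc1`, 124000 nM

All three numbers come from an ADME assay on THP-1 cells (Homo sapiens) for cytotoxicity, read by flow cytometry and propidium iodide staining, with a stated time of 72 h; on this read-out higher numbers stand for weaker inhibition and lower numbers for stronger inhibition. Compound 1 and compound 2 share one core; the single difference between them is fluoro in place of methoxy on an aromatic carbon, and in this assay the step is a 1.2-fold lower number from compound 1 to compound 2 (0.08 log units; within the scatter). Compound 3 sits on another core; the difference between the two cores is not broken down here, and the gap between compound 1 and compound 3 in this assay is within the usual scatter, as is the gap between compound 2 and compound 3.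

Compound 4, `Nc1ccc2oc(-c3ccc(F)cc3)cc(=O)c2c1`, is not yet measured. It differs from compound 3 by fluoro in place of methoxy on an aromatic carbon. Among the compounds with values here, this is the same kind of change as the one from compound 1 to compound 2, though the two places are not identical: in the first pair the group sits meta to a large group, in the second pair para to a large group.

Expectation for compound 4 in this assay rests on compound 3, whose value is 124000 nM, and on the small step of the same kind of change, a 1.2-fold lower number from compound 1 to compound 2 (0.08 log units; within the scatter). The step from compound 3 to compound 4 is therefore expected to be about a 1.2-fold lower number from compound 3 to compound 4 (0.07 log units; within the scatter). For compound 4 the estimated value is 105000 nM, with a range from 50000 nM to 220000 nM.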

Compound 4, half-maximal inhibitory concentration: 10000 nM
Beside the measured number, compound 4's estimate is 11-fold (1.02 log units) above it, and the stated range ends above it.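

In this assay, fluoro in place of methoxy on an aromatic carbon gives a 12-fold lower number from compound 3 to compound 4 (1.09 log units; beyond the scatter), and the step does not carry over in size from one core to the other: the same change on two cores in this assay, a 1.2-fold lower number (0.08 log units; within the scatter) from compound 1 to compound 2 and a 12-fold lower number (1.09 log units; beyond the scatter) from compound 3 to compound 4, 10-fold (1.02 log units) apart, beyond the scatter of two such steps. An estimate for this change on one core therefore cannot simply be transferred to the other core in this series, at least for these two pairs. The comparison does not show why the steps differ, since the cores differ and the place of the change need not match, being para to a large group in the second pair, and one pair per core gives no general rule.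

Going by these compounds, it remains open whether the large step on the core of compound 3 belongs to the arrival of fluoro or to the departure of methoxy. Chloro, methyl or a plain hydrogen at the same place on that core would help to separate these two readings.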